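This account rests on a few compounds, and the source may have more. Where it says the series, first, only, none or still open, it means among the compounds named here.

In an assay on isolated protein (strain Sprague-Dawley) for inhibition of Amine oxidase [flavin-containing] B (Rattus norvegicus), read by spectrophotometry, with a stated time of 5 min (on this read-out lower numbers stand for stronger inhibition and higher numbers for weaker inhibition), two compounds that share one core have been measured so far. Compound 1 `COc1cc(=O)oc2cc(OCc3cccc(Br)c3)ccc12` gives 5.75 nM. Compound 2 `CCOc1cc(=O)oc2cc(OCc3cccc(Br)c3)ccc12` gives 126 nM, the higher of the two numbers; its nearest neighbour is compound 1, and the step of a 22-fold higher number from compound 1 to compound 2 (1.34 log units; beyond the scatter) lies beyond the scatter. Compound 3 `NC(=O)COc1cc(=O)oc2cc(OCc3cccc(Br)c3)ccc12` has not yet been measured. It differs from compound 2 by carbamoyl in place of methyl on a saturated chain carbon bound to an oxygen on an aromatic ring; cut one bond further out, the change reads ethyl to carbamoylmethyl, ethoxy to carbamoylmethoxy. Among the compounds with values here, only one measured step bears on this place, a 22-fold higher number from compound 1 to compound 2 (1.34 log units; beyond the scatter), which shows that extending the chain at this carbon raised the number strongly. Compound 3 extends the chain once more, though with carbamoyl rather than a plain chain, and nothing measured speaks to such a group. The expectation is therefore for a further rise, smaller than the first and close to the edge of the scatter, as a 2.4-fold higher number from compound 2 to compound 3 (0.38 log units; beyond the scatter). Compound 3 is expected to give about 300 nM, within a range from 60 nM to 1500 nM.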

Compound 3, half-maximal inhibitory concentration: 8.91 nM
For compound 3 the middle estimate is 34-fold (1.53 log units) above the measured one; the measured number lies below the stated range.
By their numbers in this assay, from the lowest: compounds 1 and 3 (each within the scatter of the next); then compound 2.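

In this assay, lengthening the group at this position does not in itself go with a high number: the change from ethoxy to carbamoylmethoxy gives a 14-fold lower number from compound 2 to compound 3 (1.15 log units; beyond the scatter), a large step that reverses the direction seen on going from compound 1 to compound 2. Compared with compound 1, the result is a 1.5-fold higher number from compound 1 to compound 3 (0.19 log units; within the scatter), so the two compounds cannot be told apart here, although carbamoyl brings 1 hydrogen-bond donor and 1 hydrogen-bond acceptor to the saturated chain carbon bound to an oxygen on an aromatic ring. The high number of compound 2 therefore cannot be read as a general penalty for any extension at this place, and nothing measured here accounts for the gap between ethoxy and carbamoylmethoxy.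

The compounds shown leave open how a carboxylic acid, a nitrile or a dimethylamide would stand in the place of carbamoyl, and so which part of carbamoyl goes with the low number. They also leave open how a longer plain chain, such as propoxy, would compare with ethoxy.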